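Adding chloro to the benzyl group of compound 3

The compounds below may be only part of what the source reports. "The series", "measured", "known", "first", "only" and "open" are said of these compounds alone.

In a functional assay on SW 1116 cells (Homo sapiens) for antiproliferative activity, read by MTT assay, with a stated time of 48 h (a lower number here means a stronger inhibitor, a higher number a weaker inhibitor), compound 1 (`Fc1ccccc1CSc1nnc(-c2ccc3c(c2)OCCO3)o1`) gives 21900 nM and compound 2 (`Cc1ccccc1CSc1nnc(-c2ccc3c(c2)OCCO3)o1`) gives 23900 nM while compound 3 (`c1ccc(CSc2nnc(-c3ccc4c(c3)OCCO4)o2)cc1`) gives 31500 nM with no real separation among the three. Compound 3 therefore sits level with its two neighbours.

Compound 4 (`Clc1ccccc1CSc1nnc(-c2ccc3c(c2)OCCO3)o1`) is still unmeasured. It carries chloro in place of hydrogen on an aromatic carbon, ortho to a large group (chloro in place of hydrogen on an aromatic carbon), which turns benzyl into 2-chlorobenzyl.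

Within the data shown here, no chloro compound has been measured yet, so the closest guides are the exchanges among hydrogen, fluoro and methyl on an aromatic carbon. Hydrogen in place of fluoro gave a 1.4-fold higher number from compound 1 to compound 3 (0.16 log units; within the scatter) and hydrogen in place of methyl gave a 1.3-fold higher number from compound 2 to compound 3 (0.12 log units; within the scatter) while methyl in place of fluoro gave a 1.1-fold higher number from compound 1 to compound 2 (0.04 log units; within the scatter) as the smallest of these small steps. With steps this small, no change beyond the scatter is expected in this assay for compound 4. The expected step is a 1.3-fold lower number from compound 3 to compound 4 (0.12 log units; within the scatter) according to this estimate. Compound 4 is estimated at 24000 nM with an expected range from 13000 nM to 42000 nM around that figure.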

Compound 4, half-maximal inhibitory concentration: 29500 nM
For compound 4 the middle estimate is 1.2-fold (0.09 log units) below the measured one; measured number inside the range.
By their numbers in this assay, from the lowest: compounds 1, 2, 4 and 3 (each within the scatter of the next).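

In this assay, chloro in place of hydrogen on an aromatic carbon, ortho to a large group, gives a 1.1-fold lower number from compound 3 to compound 4 (0.03 log units; within the scatter) and so adds a larger halogen to the set without separating it from hydrogen. Set against the other two groups, compound 4 shows a 1.2-fold higher number from compound 2 to compound 4 (0.09 log units; within the scatter) and a 1.3-fold higher number from compound 1 to compound 4 (0.13 log units; within the scatter) so hydrogen, fluoro, methyl and chloro now all read as level at this place in these four compounds. No measurement shown offers an explanation for this flat picture.

Going by these compounds, whether a group of a different kind here, such as an amine, a carboxylic acid or a longer chain, would move the number beyond the scatter remains open. On these data alone, all four compounds share the same core, so the effect of a change there also remains open.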